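The source may hold more compounds than are shown below. What is called first, only, known or untested is meant among the compounds shown, and "the series" means these compounds.

For the measured compounds named here, compound 1 `CC#CC(CC(=O)O)c1ccc(OCc2ccn3cc(-c4ccc(C5CCCCC5)cc4)nc3c2)cc1` gives 559 nM in an assay on isolated protein for agonist activity at Free fatty acid receptor 1 (Homo sapiens) (a lower number here means that less compound is needed, a higher number that more compound is needed for the effect), the second highest of the three numbers measured so far. Compound 3 `CC#CC(CC(=O)O)c1ccc(OCc2ccc3nc(-c4ccc(F)cc4)cn3c2)cc1` stands nearest to it with 623 nM, a gap within the usual scatter, while compound 2 `CC#CC(CC(=O)O)c1ccc(OCc2ccc3nc(-c4ccc(OC)cc4)cn3c2)cc1` lies furthest away with 47 nM. Going by the values given here, the only measured step that alters a single place, a 13-fold higher number from compound 2 to compound 3 (1.12 log units; beyond the scatter), shows that the group on the outer aromatic ring can shift the number a great deal. Compound 4 `CC#CC(CC(=O)O)c1ccc(OCc2ccn3cc(-c4ccc(C(F)(F)F)cc4)nc3c2)cc1` differs from compound 1 by trifluoromethyl in place of cyclohexyl on an aromatic carbon. Among the compounds with values here, no measured pair tests this particular exchange, and compounds 2 and 3 carry a differently arranged core, so that step bears on compound 4 only as a sign that this position matters. Compound 4 is therefore expected to remain close to compound 1, with a 1.2-fold lower number from compound 1 to compound 4 (0.09 log units; within the scatter), and the direction is uncertain. The estimate for compound 4 in this assay is 450 nM, with a range from 120 nM to 1700 nM.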

Compound 4, half-maximal effective concentration: 674 nM
For compound 4 the middle estimate is 1.5-fold (0.18 log units) below the measured one, within the range that was stated.
By their numbers in this assay, from the lowest: compound 2; then compounds 1, 3 and 4 (each within the scatter of the next).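

In this assay, trifluoromethyl in place of cyclohexyl on the aromatic carbon gives a 1.2-fold higher number from compound 1 to compound 4 (0.08 log units; within the scatter), so on the core of compound 1 these two groups cannot be told apart at this place. The earlier compounds shown here showed, on a differently arranged core, that an exchange at the outer aromatic ring can matter, with a 13-fold higher number from compound 2 to compound 3 (1.12 log units; beyond the scatter); here, a group with a six-membered ring of six carbon atoms and a group with no ring and four heavy atoms give numbers within the scatter of each other. Nothing given explains this result.

Going by these compounds, it remains open whether methoxy or fluoro would separate from these two groups on the core of compound 1, as they separate from each other on the other core. Also open, on these data alone, is how an amine, a carboxylic acid or a longer alkyl chain would behave at this place.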